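Anilino analogue of compound 3: working notes

The compounds below may be only part of what the source reports. "The series", "measured", "known", "first", "only" and "open" are said of these compounds alone.

Measured in a functional assay on ECa-109 cells for inhibition, with ECa-109 cell line (Homo sapiens) as the target, read by sulforhodamine B assay; on this read-out higher numbers stand for weaker inhibition and lower numbers for stronger inhibition:
- compound 1 `O=C1C=C(Nc2cccc(F)c2)C(=O)c2c1nc1n2[C@H]2OC[C@@H](O)[C@H]2OC1`: 7030 nM
- compound 2 `CCOc1ccccc1NC1=CC(=O)c2nc3n(c2C1=O)[C@H]1OC[C@@H](O)[C@H]1OC3`: 4630 nM
- compound 3 `Cc1ccc(NC2=CC(=O)c3nc4n(c3C2=O)[C@H]2OC[C@@H](O)[C@H]2OC4)cc1`: 3480 nM

Compound 3 sits at the low end of these numbers, level with compound 2: a 1.3-fold lower number from compound 2 to compound 3 (0.12 log units; within the scatter). The gap to compound 1 is modest: a 2.0-fold lower number from compound 1 to compound 3 (0.31 log units; beyond the scatter).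

The next analogue is compound 4 `O=C1C=C(Nc2ccccc2)C(=O)c2c1nc1n2[C@H]2OC[C@@H](O)[C@H]2OC1`. It differs from compound 3 by hydrogen in place of methyl on an aromatic carbon, which is hydrogen in place of methyl on an aromatic carbon, or 4-methylphenyl to phenyl. Among the measured compounds shown here, no measured step makes exactly this change. The closest evidence is the swaps of the aromatic group on the amine nitrogen, which also include a 1.5-fold lower number from compound 1 to compound 2 (0.18 log units; within the scatter). For the measured compounds named here, these steps are small, and only the one into compound 3 from compound 1 clears the scatter. No step beyond the scatter is therefore expected in this assay, although a slightly higher number is possible.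

The estimated step is a 1.3-fold higher number from compound 3 to compound 4 (0.12 log units; within the scatter).

Compound 4 is expected at 4600 nM, with an estimated range of 2300 nM to 9000 nM.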

Compound 4, half-maximal inhibitory concentration: 4970 nM
For compound 4 the middle estimate is 1.1-fold (0.03 log units) below the measured one; the measured number falls inside the stated range.
By their numbers in this assay, from the lowest: compounds 3, 2, 4 and 1 (each within the scatter of the next, the first and the last beyond it).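

In this assay, compound 4 gives the series its unsubstituted phenyl on the amine nitrogen, and losing the methyl para to a large group stays within the scatter: a 1.4-fold higher number from compound 3 to compound 4 (0.15 log units; within the scatter). Hydrogen in place of ethoxy gives a 1.1-fold higher number from compound 2 to compound 4 (0.03 log units; within the scatter), and hydrogen in place of fluoro gives a 1.4-fold lower number from compound 1 to compound 4 (0.15 log units; within the scatter), so none of the three groups separates from hydrogen on this read-out, although compound 1 and compound 3 lie just beyond the scatter of each other. No supporting data bear on why these steps are so small.

The compounds shown leave open whether an amine or a carboxylic acid on the phenyl ring, or a longer chain in place of the methyl, would give a step beyond the scatter. Also open, going by these compounds, is whether a cyclohexyl group on the amine nitrogen would behave like the aromatic groups.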